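A few compounds are considered here, and "the series" means these few. Any claim that something is new, unique, unknown or untested is made for them only; others in the source may bear on it.

Compound 1, `Oc1cc(-c2ccccc2)nc2c(O)cccc12`: > 10 ug/mL
Compound 2, `CC(C)COc1cc(-c2ccccc2)nc2ccccc12`: > 10 ug/mL
Compound 3, `Oc1cc(-c2ccccc2)nc2cc(F)ccc12`: 0.96 ug/mL

Of the compounds shown here, three sharing one core have been tested in a functional assay on A549 cells (Homo sapiens) for cytotoxicity; a lower number here means that less compound is needed, a higher number that more compound is needed for the effect. Compound 1 gives only the limit > 10 ug/mL, not a number. Compound 2 likewise gives only the limit > 10 ug/mL, so its true value is not known, only that it lies outside the range the assay reports. For the measured compounds named here, compound 3 is the one compound with a measured number, 0.96 ug/mL. So compound 2 stands among the weaker side of this small set, at the limit of > 10 ug/mL in this assay, at which 2 of the 3 values shown sit, where most of the values sit.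

Compound 4, `CCCCOc1cc(-c2ccccc2)nc2ccccc12`, has not yet been measured. It differs from compound 2 in one place, (propyl in place of isopropyl on a saturated chain carbon bound to an oxygen on an aromatic ring). The same atoms are present, joined in a different order, so the change is a small one, from a branched chain to a straight one of the same length.

Going by the values given here, no step between measured compounds is available to guide the expectation. For a rearrangement this modest, no change beyond the usual scatter is expected in this assay, and the estimated step that the limit leaves unreadable from compound 2 to compound 4 is put close to none. Compound 4 is expected at about 15 ug/mL, with a range from 5 ug/mL to 50 ug/mL, and a fair chance that the assay again reports only a limit.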

Compound 4, half-maximal effective concentration: > 10 ug/mL
Compound 4 gave a limit, no number (the forecaster's own chance of this, stated with the estimate: 65%); the middle value lies beyond the limit too.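

In this assay compound 4 gives > 10 ug/mL, which is a limit and not a number. Compound 2 gives > 10 ug/mL, also a limit, so no step can be read between these two compounds. The compounds shown leave open whether propyl in place of isopropyl changes the effect at all, and most values remain limits: the limit of > 10 ug/mL in this assay, at which 3 of the 4 values shown sit.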